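Methoxy to methylsulfonyl on the chain: working notes

This account rests on a few compounds, and the source may have more. Where it says the series, first, only, none or still open, it means among the compounds named here.

Measured in a functional assay on HCT-116 cells (Homo sapiens) for antiproliferative activity; on this read-out higher numbers stand for weaker inhibition and lower numbers for stronger inhibition:
- Compound 1 `O=C(CCCCCCC(=O)Nc1ccc(Nc2nc(-c3cn[nH]c3)c3cc[nH]c3n2)cc1)NO`: 14400 nM
- Compound 2 `COCCn1cc(-c2nc(Nc3ccc(NC(=O)CCCCCCC(=O)NO)cc3)nc3[nH]ccc23)cn1`: 9400 nM

Compound 2 at 9400 nM lies within the scatter of compound 1, so the two values do not separate. Compound 3 `CS(=O)(=O)CCn1cc(-c2nc(Nc3ccc(NC(=O)CCCCCCC(=O)NO)cc3)nc3[nH]ccc23)cn1` turns the 2-methoxyethyl into 2-(methylsulfonyl)ethyl: methylsulfonyl in place of methoxy on a saturated chain carbon, two bonds along the chain from an aromatic nitrogen. For the measured compounds named here, no measured step covers this exchange directly. Going by the values given here, the nearest evidence is the one step on the same group, with 2-methoxyethyl in place of hydrogen on an aromatic nitrogen: a 1.5-fold lower number from compound 1 to compound 2 (0.19 log units; within the scatter). That step gives no direction for compound 3, so no change beyond the scatter is expected in this assay. The expected step is a 1.0-fold lower number from compound 2 to compound 3 (0.02 log units; within the scatter). For compound 3 the estimated value is 9000 nM, with an expected range of 3500 nM to 22000 nM.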

Compound 3, half-maximal inhibitory concentration: > 100000 nM
Compound 3: no number, only a limit; the forecaster's own chance of this, stated with the estimate: 5%; middle value at least 11-fold (1.04 log units) away from the limit.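

In this assay the result for compound 3 is a limit and not a number: the limit of > 100000 nM in this assay, at which 1 of the 3 values shown sits.

The earlier compounds shown here left this position looking indifferent, but the end group of the chain does matter here: methylsulfonyl in place of methoxy gives an at least 10-fold higher number from compound 2 to compound 3 (1.02 log units; beyond the scatter). Set against hydrogen on the aromatic nitrogen, 2-(methylsulfonyl)ethyl gives an at least 6.9-fold higher number from compound 1 to compound 3 (0.84 log units; beyond the scatter), whereas 2-methoxyethyl stayed within the scatter, so in these three compounds the outcome follows the end group and not the mere presence of a chain.

Which feature of the methylsulfonyl group goes with this step stays open, and the full size of both steps cannot be read past the limit. Also open, going by these compounds, is how an amine or a carboxylic acid at the end of the same chain, or a longer chain ending in methoxy, would read in this assay.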